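Swapping an ethyl ester for a primary amide

This account rests on a few compounds, and the source may have more. Where it says the series, first, only, none or still open, it means among the compounds named here.

Compound 1 has the structure `CCOC(=O)c1sc(-c2cccc(NC(=O)c3ccc(C(C)(C)C)cc3)c2)nc1Nc1ccc(N2CCN(C)CC2)cc1`. In a functional assay on Ramos cells (Homo sapiens) for antiproliferative activity, read by CCK-8 assay, with a stated time of 72 h (on this read-out lower numbers stand for stronger inhibition and higher numbers for weaker inhibition), compound 1 gives "not determined" (no result reported), so its position on the scale is simply unknown. The only measured point in this set is compound 2, with the structure `CCOC(=O)c1sc(-c2cccc(NC(=O)c3ccccc3F)c2)nc1Nc1ccc(N2CCN(C)CC2)cc1`; in this assay compound 2 gives 2000 nM. Among the measured compounds shown here, compound 2 differs from compound 1 in the amide-linked aryl group, and no step between measured compounds has been worked out, so its value serves only as a rough anchor for the series and not as a direct comparison with compound 1.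

The unmeasured compound 3 has the structure `CN1CCN(c2ccc(Nc3nc(-c4cccc(NC(=O)c5ccc(C(C)(C)C)cc5)c4)sc3C(N)=O)cc2)CC1`. It arises from compound 1 through the change (amino in place of ethoxy on a carbonyl carbon), that is, amino in place of ethoxy on a carbonyl carbon. For the measured compounds named here, no measured pair shows the effect of this change. There is thus no basis for expecting a step beyond the usual scatter in either direction. On that footing, compound 3 is expected to give about 1000 nM in this assay, with a plausible range from 200 nM to 6000 nM.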

Compound 3, half-maximal inhibitory concentration: 8600 nM
Beside the measured number, compound 3's estimate is 8.6-fold (0.93 log units) below it; measured number above the stated range.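

Compound 1 has no single number to set against compound 3, and compound 2 differs from compound 3 in more than one place, so no step can be read from these compounds. From the compounds shown here alone, whether amino in place of ethoxy on a carbonyl carbon shifts activity, and in which direction, stays open. No supporting data bear on the value of compound 3.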